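Swapping One Ring Nitrogen on the Shared Core

A few compounds are considered here, and "the series" means these few. Any claim that something is new, unique, unknown or untested is made for them only; others in the source may bear on it.

Measured so far in an ADME assay on RAW264.7 cells (Mus musculus) for cytotoxicity, read by MTT assay, with a stated time of 48 h, tested at 50 uM; a lower number here means less inhibition, a higher number more inhibition at the concentration tested (going by the name of the read-out):
Compound 1, `N=C1S/C(=C\c2ccc(OCc3ccccc3)cc2)C(=O)N1c1ccc(Cl)cc1Cl`: 13.8%
Compound 2, `N=C1S/C(=C\c2ccc(OCc3ccccc3)cc2)C(=O)N1c1ncccn1`: 26.6%

Compound 2 has the higher of the two numbers in this assay, and the gap to compound 1 is beyond the usual scatter. Within the data shown here, the one measured step, a number 12.8 percentage points higher from compound 1 to compound 2 (beyond the scatter), came with pyrimidin-2-yl in place of 2,4-dichlorophenyl on an amide-type nitrogen in a ring. That step is the whole of what the data show.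

Compound 3, `N=C1S/C(=C\c2ccc(OCc3ccccc3)cc2)C(=O)N1c1ccccn1`, is a close relative of compound 2. The difference is pyridin-2-yl in place of pyrimidin-2-yl on an amide-type nitrogen in a ring. Among the measured compounds shown here, no measured step trades one six-membered aromatic ring with 2 hetero atoms for one with 1 hetero atom at this place; the measured step exchanged a quite different group. So there is no footing for a direction, and the expectation is a step that stays within the usual scatter.

Compound 3 is therefore estimated to give about 24% in this assay, with a likely range from 10% to 38%. This estimate means an expected step of a number 2.6 percentage points lower from compound 2 to compound 3 (within the scatter).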

Compound 3, a percentage reported as inhibition, at one concentration (the size of the read-out at that concentration, not a potency): 37.2%
Compound 3: middle estimate off by 13.2 percentage points, on the low side; the measured number falls inside the stated range.
By their numbers in this assay, from the lowest: compound 1; then compound 2; then compound 3.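

At this position, on an amide-type nitrogen in a ring, exchanging one six-membered aromatic ring for another of the same size is not a silent change: in this assay, pyridin-2-yl in place of pyrimidin-2-yl gives a number 10.6 percentage points higher from compound 2 to compound 3 (beyond the scatter). Replacing 2,4-dichlorophenyl with pyridin-2-yl gives a number 23.4 percentage points higher from compound 1 to compound 3 (beyond the scatter), so the three groups now form an order with every step beyond the scatter, and the ring with 1 hetero atom stands above the ring with 2 hetero atoms rather than below it. No measurement shown here explains why the numbers fall in this order.

On these data alone, three groups at one position cannot show whether this order reflects a general trend, and it remains open where an unsubstituted phenyl ring or pyridin-4-yl would fall. As far as these compounds go, the benzyloxy group is also the same in all three compounds, so it is unknown whether the order would hold if a methoxy group or a carboxylic acid stood in its place.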